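A few compounds are considered here, and "the series" means these few. Any claim that something is new, unique, unknown or untested is made for them only; others in the source may bear on it.

Values in a functional assay on DU-145 cells (Homo sapiens) for inhibition; a higher number here means a weaker inhibitor, a lower number a stronger inhibitor:
compound 1 `Oc1cccc(-c2cc(-c3ccccc3C(F)(F)F)cc(-c3ccccc3O)n2)c1`: 7250 nM
compound 2 `Oc1cccc(-c2cc(-c3cccc(C(F)(F)F)c3)cc(-c3ccccc3O)n2)c1`: 13000 nM
compound 3 `Oc1ccc(-c2cc(-c3ccccc3C(F)(F)F)cc(-c3ccccc3O)n2)cc1`: 6690 nM

Compound 2 differs from compound 1 by 3-(trifluoromethyl)phenyl in place of 2-(trifluoromethyl)phenyl on an aromatic carbon; the step is a 1.8-fold higher number from compound 1 to compound 2 (0.25 log units; within the scatter). Compound 3 differs from compound 1 in the core, (4-hydroxyphenyl in place of 3-hydroxyphenyl on an aromatic carbon), with a 1.1-fold lower number from compound 1 to compound 3 (0.03 log units; within the scatter). All three values sit within the usual scatter of one another, so no order among them is claimed.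

Compound 4 `Oc1ccc(-c2cc(-c3cccc(C(F)(F)F)c3)cc(-c3ccccc3O)n2)cc1` is not yet measured in this assay. It differs from compound 3 by 3-(trifluoromethyl)phenyl in place of 2-(trifluoromethyl)phenyl on an aromatic carbon. This is the same kind of change as from compound 1 to compound 2, but the surroundings differ: in compound 3 the place is meta to a 4-hydroxyphenyl group, where in compound 1 it is meta to a 3-hydroxyphenyl group. For compound 4 a step of a 1.8-fold higher number from compound 3 to compound 4 (0.25 log units; within the scatter) is expected, resting on the earlier step of a 1.8-fold higher number from compound 1 to compound 2 (0.25 log units; within the scatter) and on compound 3 at 6690 nM. Compound 4 is therefore estimated at 12000 nM, expected between 5000 nM and 30000 nM.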

Compound 4, half-maximal inhibitory concentration: > 50000 nM
Compound 4: a limit, no number (the forecaster's own chance of this, stated with the estimate: 3%); middle value at least 4.1-fold (0.61 log units) from the limit.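

In this assay, the change to 3-(trifluoromethyl)phenyl does not carry over unchanged from the core of compound 1 to the core of compound 3, with an at least 7.4-fold higher number from compound 3 to compound 4 (0.87 log units; beyond the scatter): the same change on two cores in this assay, a 1.8-fold higher number (0.25 log units; within the scatter) from compound 1 to compound 2 and an at least 7.4-fold higher number (0.87 log units; beyond the scatter) from compound 3 to compound 4, at least 4.1-fold (0.61 log units) apart, beyond the scatter of two such steps. The change to 4-hydroxyphenyl likewise depends on its surroundings, with an at least 3.8-fold higher number from compound 2 to compound 4 (0.58 log units; beyond the scatter): the same change on two cores in this assay, a 1.1-fold lower number (0.03 log units; within the scatter) from compound 1 to compound 3 and an at least 3.8-fold higher number (0.58 log units; beyond the scatter) from compound 2 to compound 4, at least 4.1-fold (0.61 log units) apart, beyond the scatter of two such steps. Compound 4 at > 50000 nM is a limit of the assay and not a number, so the full size of both steps stays unknown, and this single set of four compounds shows no reason for the difference and no general rule.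

The compounds shown vary only the positions of the trifluoromethyl and hydroxyl groups. Going by these compounds, whether the same dependence holds with a nitrile in place of trifluoromethyl, or an amine in place of hydroxyl, remains open.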